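Adding a Bromine to Compound 3: What the Numbers Suggest

This account rests on a few compounds, and the source may have more. Where it says the series, first, only, none or still open, it means among the compounds named here.

Compound 1, `Nc1nc(N2CCCC2)sc1C(=O)/C=C/c1ccccc1`, gives 29.6 ug/mL in a functional assay on HepG2 cells (Homo sapiens) for antiproliferative activity, read by MTT assay, with a stated time of 48 h; on this read-out higher numbers stand for weaker inhibition and lower numbers for stronger inhibition.
Compound 2, `Nc1nc(N2CCCC2)sc1C(=O)/C=C/c1ccc(Br)cc1`, gives 30 ug/mL in this assay.
Compound 3, `Nc1nc(N2CCCCC2)sc1C(=O)/C=C/c1ccccc1`, gives 16.6 ug/mL in this assay.

Among these three numbers compound 3 has the lowest, yet its gaps to the other two lie within the scatter, so no order among them can be claimed. The step of a 1.8-fold lower number from compound 1 to compound 3 (0.25 log units; within the scatter) shows how little the change of the saturated ring moved the read-out.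

Compound 4, `Nc1nc(N2CCCCC2)sc1C(=O)/C=C/c1ccc(Br)cc1`, differs from compound 3 by bromo in place of hydrogen on an aromatic carbon. Among the measured compounds shown here, the one measured step bearing on this change is a 1.0-fold higher number from compound 1 to compound 2 (0.01 log units; within the scatter), which left the number essentially where it was. Carrying the same bromo-for-hydrogen exchange over to compound 3, the account expects no shift beyond the scatter in this assay for compound 4, with the estimated step being a 1.0-fold higher number from compound 3 to compound 4 (0.01 log units; within the scatter). Compound 4 is therefore estimated at 17 ug/mL, with a likely range from 9 ug/mL to 33 ug/mL.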

Compound 4, half-maximal inhibitory concentration: 17.4 ug/mL
The estimate for compound 4 lay 1.0-fold (0.01 log units) below the measured number, and the stated range covers the measured number.
By their numbers in this assay, from the lowest: compounds 3, 4, 1 and 2 (each within the scatter of the next).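

Bromo in place of hydrogen on an aromatic carbon, para to a large group, now gives a 1.0-fold higher number from compound 3 to compound 4 (0.02 log units; within the scatter), so the change has been read with piperidin-1-yl as well as with pyrrolidin-1-yl. The two readings agree in this assay: the same change on two cores in this assay, a 1.0-fold higher number (0.01 log units; within the scatter) from compound 1 to compound 2 and a 1.0-fold higher number (0.02 log units; within the scatter) from compound 3 to compound 4, 1.0-fold (0.01 log units) apart, within the scatter of two such steps. Among the compounds shown here, the exchange of the saturated ring, earlier seen only on the phenyl compounds, also repeats on the 4-bromophenyl pair, with a 1.7-fold lower number from compound 2 to compound 4 (0.24 log units; within the scatter): the same change on two cores in this assay, a 1.8-fold lower number (0.25 log units; within the scatter) from compound 1 to compound 3 and a 1.7-fold lower number (0.24 log units; within the scatter) from compound 2 to compound 4, 1.0-fold (0.01 log units) apart, within the scatter of two such steps.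

Among the compounds shown, bromo is the only group other than hydrogen at this position, so it remains open whether an amine, a methoxy group or a carboxylic acid there would also stay within the scatter. From the compounds shown here alone, it also remains open what a morpholine ring in place of the saturated ring would do to the number.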